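The compounds below may be only part of what the source reports. "The series", "measured", "known", "first", "only" and "open" are said of these compounds alone.

Measured so far:

compound 1, `Nc1nc(Cl)c2ncn(Cc3ccc(CCl)cc3)c2n1`: > 100000 nM, a limit of the assay rather than a number
compound 2, `ClCc1cccc(Cn2cnc3c(Cl)nc(Cl)nc32)c1`: 6450 nM
compound 3, `ClCc1ccc(Cn2cnc3c(Cl)nc(Cl)nc32)cc1`: 69200 nM

All three were tested in a functional assay on UACC-257 cells (Homo sapiens) for cytotoxicity, read by sulforhodamine B assay, with a stated time of 48 h; a higher number here means that more compound is tolerated, a lower number that less compound is tolerated. Compound 1 reaches only a limit there, (the limit of > 100000 nM in this assay, at which 1 of the 3 values shown sits), so no number is known for it. Of the two numbers that are known, compound 2 gives the lower one and compound 3 the higher one. The two have the same atoms joined differently, and the difference between their cores is not broken down here.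

Compound 3 and compound 1 differ in one place: amino in place of chloro on an aromatic carbon. This change moved the read-out by an at least 1.4-fold higher number from compound 3 to compound 1 (0.15 log units; that floor lies within the scatter), and since compound 1 sits at the limit, only the floor of that step is known.

The unmeasured compound 4, `Nc1nc(Cl)c2ncn(Cc3cccc(CCl)c3)c2n1`, carries the same change made on compound 2: amino in place of chloro on an aromatic carbon. The surroundings of the place are the same in both pairs, so this is the same change.

From compound 2 to compound 4 the step is expected to be a 6.2-fold higher number from compound 2 to compound 4 (0.79 log units; beyond the scatter). This expectation rests on the floor set by an at least 1.4-fold higher number from compound 3 to compound 1 (0.15 log units; that floor lies within the scatter), together with the fact that compound 1 reached only a limit, (the limit of > 100000 nM in this assay, at which 1 of the 3 values shown sits), which leaves the true size of the step open. Compound 4 is therefore estimated at 40000 nM in this assay, with a range expected from 10000 nM to 200000 nM.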

Compound 4, concentration lethal to 50% of the cells: 49000 nM
Estimate against measurement, compound 4: 1.2-fold (0.09 log units) below; the measured number falls inside the stated range.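

In this assay, amino in place of chloro on the core of compound 2 gives a 7.6-fold higher number from compound 2 to compound 4 (0.88 log units; beyond the scatter), so on this core the swap clearly raises the amount of compound that is tolerated. On the other core, compound 1 gives > 100000 nM, which is a limit of the assay and not a number, so the step that ends there is known only as a floor and its true size stays hidden. The result on compound 2 therefore fits with the change carrying over from one core to the other, but it does not show that the change has the same size on both, and two pairs of compounds are too few to set a rule for the series: the same change on two cores in this assay, an at least 1.4-fold higher number (0.15 log units; that floor lies within the scatter) from compound 3 to compound 1 and a 7.6-fold higher number (0.88 log units; beyond the scatter) from compound 2 to compound 4; the limit leaves it open whether they differ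

The compounds shown leave open what other groups would do at the same place between two ring nitrogen atoms, such as a methylamino group or a hydroxyl group in place of the amino. They also leave open whether the step would hold if the chloromethyl group were exchanged for a plain methyl group or a hydroxymethyl group.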